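Thiophene attachment point swap in a cytotoxicity series

A few compounds are considered here, and "the series" means these few. Any claim that something is new, unique, unknown or untested is made for them only; others in the source may bear on it.

Measured compounds:
compound 1, `Oc1cccc(-c2cc(-c3cccc(Cl)c3)nc(-c3ccccn3)c2)c1`: "not determined" (no result reported) in an ADME assay on HEK293 cells (Homo sapiens) for cytotoxicity, read by CCK-8 assay and cell counting, with a stated time of 2 days; on this read-out lower numbers stand for stronger inhibition and higher numbers for weaker inhibition
compound 2, `Oc1ccc(-c2cc(-c3cccs3)nc(-c3ccccc3Cl)c2)cc1`: 5220 nM

Working notes. In this assay, within the data shown here, compound 2 gives 5220 nM, and this is the only number available; compound 1 carries "not determined" (no result reported), so there is no pair of measured compounds to set a step against, and nothing can be said about the direction any change takes.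

Compound 3, `Oc1ccc(-c2cc(-c3ccsc3)nc(-c3ccccc3Cl)c2)cc1`, is the next entry. It differs from compound 2 by thiophen-3-yl in place of thiophen-2-yl on an aromatic carbon. The two share the same atoms joined differently, with the same donor and acceptor count, so no move beyond the usual scatter is expected in this assay from this change. Compound 3 is therefore expected to land near compound 2, with an estimated step of a 1.0-fold lower number from compound 2 to compound 3 (0.00 log units; within the scatter). The estimate for compound 3 is 5200 nM, with a range from 2600 nM to 10400 nM.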

Compound 3, half-maximal inhibitory concentration: 5930 nM
Compound 3: middle estimate off by 1.1-fold (0.06 log units), on the low side; the range from low to high includes it.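

Among these compounds, the swap of thiophen-2-yl for thiophen-3-yl, on the aromatic carbon next to the ring nitrogen, gives the first readable step in this assay: a 1.1-fold higher number from compound 2 to compound 3 (0.06 log units; within the scatter) and so stays within the scatter. For this one pair, moving the thiophene attachment point leaves the read-out unchanged, which is a finding about this position that compound 2 alone could not give. No supporting measurement bears on this result, and it stays without explanation.

Steps involving compound 1 cannot be read, and a single pair says nothing about whether a different group at this position, such as an amine, a carboxylic acid or a longer alkyl chain, would shift the number. Also open, going by these compounds, is how the read-out responds when the hydroxyl of the 4-hydroxyphenyl group gives way to a methoxy group, or when the 2-chlorophenyl group is replaced.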